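Serine Carbonyl Analogues in a Human Liver Microsome Test

This account rests on a few compounds, and the source may have more. Where it says the series, first, only, none or still open, it means among the compounds named here.

Compound 1: `O=C(O)[C@H](CO)NC(=O)N1CCCC1`; "not determined" (no result reported)
Compound 2: `O=C(CCO)N[C@@H](CO)C(=O)O`; 96%

Both compounds share a serine core whose nitrogen carries a carbonyl group. For the measured compounds named here, in an ADME assay on microsomes from liver (Homo sapiens) for metabolic stability, with a stated time of 30 min (a lower number here means that less of the compound is left, a higher number that more of the compound is left), compound 2 gives 96%, which is the only number available here; compound 1 was entered in the same test but no result was reported for it, so compound 2 cannot be placed against any other measured value.

Compound 3, `COC(=O)N[C@@H](CO)C(=O)O`, is the next step from compound 2: methoxy in place of 2-hydroxyethyl on a carbonyl carbon. Going by the values given here, no step between measured compounds is available to guide the size of this change. Since compound 2 already sits near the top of what this assay can show, compound 3 is expected to stay close, with a step of a number 6 percentage points lower from compound 2 to compound 3 (within the scatter) that is expected to lie within the usual scatter or only a little below it. For compound 3 the expected value is 90%, estimated to fall between 75% and 100%.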

Compound 3, percent of the compound remaining: 43%
Beside the measured number, compound 3's estimate is 47 percentage points above it; the measured number lies below the stated range.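

In this assay the group on a carbonyl carbon turns out to matter greatly: methoxy in place of 2-hydroxyethyl gives a number 53 percentage points lower from compound 2 to compound 3 (beyond the scatter) and shows that the high value of compound 2 does not carry over to a close relative. The earlier compounds shown here could not show this, as compound 2 stood alone with a number and compound 1 has none. No measurement at hand explains the drop.

As far as these compounds go, this single swap removes a hydrogen-bond donor and shortens the group together, and it remains open which of the two changes goes with the drop. An ethoxy group, an amine or a longer chain ending in a hydroxyl at this carbonyl carbon would help to tell these two changes apart.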